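Working notes: from phenylsulfanyl to methylamino in the series

The source may hold more compounds than are shown below. What is called first, only, known or untested is meant among the compounds shown, and "the series" means these compounds.

Measured in a functional assay on HeLa cells (Homo sapiens) for cytotoxicity; a higher number here means a weaker inhibitor, a lower number a stronger inhibitor:
- compound 1 `CC1=CCC[C@H]2[C@](C)(CC3=CC(=O)C=CC3=O)[C@@H](C)CC[C@]12C`: 26800 nM
- compound 2 `COC1=CC(=O)C=C(C[C@]2(C)[C@@H](C)CC[C@]3(C)C(C)=CCC[C@@H]23)C1=O`: 13300 nM
- compound 3 `CC1=CCC[C@H]2[C@](C)(CC3=CC(=O)C=C(Sc4ccccc4)C3=O)[C@@H](C)CC[C@]12C`: 54800 nM

Compound 3 has the highest number of the three, and its steps to both other compounds lie beyond the scatter. The next change leads to compound 4 `CNC1=CC(=O)C=C(C[C@]2(C)[C@@H](C)CC[C@]3(C)C(C)=CCC[C@@H]23)C1=O`: methylamino in place of phenylsulfanyl on a double-bonded ring carbon. In words, this is methylamino in place of phenylsulfanyl on a double-bonded ring carbon.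

Within the data shown here, three measured steps bear on this change. Phenylsulfanyl in place of hydrogen gave a 2.0-fold higher number from compound 1 to compound 3 (0.31 log units; beyond the scatter), and phenylsulfanyl in place of methoxy gave a 4.1-fold higher number from compound 2 to compound 3 (0.61 log units; beyond the scatter). Both steps are modest. Methoxy in place of hydrogen gave a 2.0-fold lower number from compound 1 to compound 2 (0.30 log units; within the scatter), which stays within the scatter. So far, then, both compounds without phenylsulfanyl have lower numbers than compound 3, and neither goes against this. Among the measured compounds shown here, no measured compound carries methylamino, so this guide is only indirect.

In this assay, a modest step to a lower number is expected, similar in size to the two steps involving phenylsulfanyl. The estimated change is a 3.4-fold lower number from compound 3 to compound 4 (0.53 log units; beyond the scatter). For compound 4 the estimated value is 16000 nM, with an expected range of 5000 nM to 45000 nM.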

Compound 4, half-maximal inhibitory concentration: 11300 nM
Compound 4: the middle estimate sits 1.4-fold (0.15 log units) above what was measured, within the range that was stated.
By their numbers in this assay, from the lowest: compounds 4, 2 and 1 (each within the scatter of the next, the first and the last beyond it); then compound 3.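

In this assay, methylamino in place of phenylsulfanyl gives a 4.8-fold lower number from compound 3 to compound 4 (0.69 log units; beyond the scatter), so the step away from phenylsulfanyl on this double-bonded ring carbon is not tied to methoxy and now holds for a nitrogen-linked group as well. Against hydrogen, methylamino gives a 2.4-fold lower number from compound 1 to compound 4 (0.38 log units; beyond the scatter), a step beyond the scatter, whereas the methoxy step a 2.0-fold lower number from compound 1 to compound 2 (0.30 log units; within the scatter) stays within it. Methylamino and methoxy still cannot be separated, as a 1.2-fold lower number from compound 2 to compound 4 (0.07 log units; within the scatter) lies within the scatter, and compound 3 remains the weakest of the four, with its steps to all three others beyond the scatter.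

Methylsulfanyl would show whether the higher number of compound 3 goes with the sulfur link or with the phenyl ring, a question these four compounds cannot settle, as phenylsulfanyl is the only sulfur-linked group among them. Dimethylamino and a longer chain on the nitrogen, such as propylamino, also remain open, so the series does not yet show whether the amine hydrogen or the size of the alkyl group matters at this position.

No measurement at hand accounts for these differences.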